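A Methoxy for a Chloro on a Weakly Active Core

The source may report more compounds than this note shows. Statements on the series, on what has been measured and on what is new or still open speak of the compounds shown alone.

Going by the values given here, compound 1 `O=C1COc2ccc(-c3cnc(Cl)c(NS(=O)(=O)c4ccc(F)cc4)c3)cc2N1c1ccccc1` is one of two compounds tested in a functional assay on A-375 cells (Homo sapiens) for antiproliferative activity, read by MTT assay, with a stated time of 72 h; on this read-out lower numbers stand for stronger inhibition and higher numbers for weaker inhibition; in this assay compound 1 gives 36900 nM, the only number reported. Compound 2 `O=C1COc2ccc(-c3cnc(Cl)c(NS(=O)(=O)c4ccc(F)cc4)c3)cc2N1C1CCCCC1` carries a cyclohexyl in place of the phenyl on the amide-type nitrogen in the ring, and in this assay compound 2 returns only a limit of the assay, > 40000 nM. The step of an at least 1.0-fold higher number from compound 1 to compound 2 (0.03 log units; that floor lies within the scatter) therefore rests on that limit of > 40000 nM in this assay, at which 1 of the 2 values shown sits, and says little beyond that neither compound inhibits strongly.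

Compound 3 `COc1ncc(-c2ccc3c(c2)N(c2ccccc2)C(=O)CO3)cc1NS(=O)(=O)c1ccc(F)cc1` differs from compound 1 at another place: methoxy in place of chloro on an aromatic carbon. Among the compounds with values here, no measured step touches this position, so the only guide is the weak starting point of compound 1 and the step of an at least 1.0-fold higher number from compound 1 to compound 2 (0.03 log units; that floor lies within the scatter), which left the number in the same weak range. One expects no step beyond the scatter, a 1.2-fold lower number from compound 1 to compound 3 (0.09 log units; within the scatter). Compound 3 is estimated at 30000 nM, between 10000 nM and 90000 nM, with a fair chance that the assay reports only a limit.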

Compound 3, half-maximal inhibitory concentration: 15200 nM
Estimate against measurement, compound 3: 2.0-fold (0.30 log units) above, within the range that was stated.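

In this assay, methoxy in place of chloro on the aromatic carbon next to the ring nitrogen gives a 2.4-fold lower number from compound 1 to compound 3 (0.39 log units; beyond the scatter), the only step shown that lies beyond the scatter and is read between two actual numbers. This position, ortho to a ((4-fluorophenyl)sulfonyl)amino group and para to a large group, is therefore one where a replacement moves the number, though only modestly, and compound 3 at 15200 nM still inhibits weakly. Nothing measured for these compounds says why the number moves.

Going by these compounds, what an ethoxy group, an amine or a nitrile would do on this same carbon stays open, as does whether a longer chain in place of methoxy would carry the number further down. Also open, on these data alone, is whether methoxy would move the number in the same way on the core of compound 2, whose value of > 40000 nM is a limit of the assay.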